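Three Limits and a Piperidine Replacement

The source may hold more compounds than are shown below. What is called first, only, known or untested is meant among the compounds shown, and "the series" means these compounds.

The measured compounds and their values:
compound 1, `COc1ccc(Nc2ncc3c(n2)N(C2CCCC2)CC(=O)N3C)cc1`: in a functional assay on MDA-MB-231 cells (Homo sapiens) for inhibition, read by MTT assay, with a stated time of 48 h (a higher number here means a weaker inhibitor, a lower number a stronger inhibitor), compound 1 reaches only the limit > 30000 nM.
compound 2, `CCN1C(=O)CN(C2CCCC2)c2nc(Nc3ccc(OC)cc3)ncc21`: in this assay compound 2 also reaches only the limit > 30000 nM.
compound 3, `CN1CCN(c2ccc(Nc3ncc4c(n3)N(C3CCCC3)CC(=O)N4)nc2)CC1`: in this assay compound 3 likewise reaches only the limit > 30000 nM.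

Compound 1 therefore stands at the limit of this assay, not at a number, and the two further values shown are limits as well. Going by the values given here, the single one-place step among the measured compounds, a step that the two limits leave unreadable from compound 1 to compound 2, runs between two limits and cannot be read. The evidence available is the limit of > 30000 nM in this assay, at which 3 of the 3 values shown sit, which says nothing about the direction or size of any step.

The compound not yet measured is compound 4, `CC1CCN(c2ccc(Nc3ncc4c(n3)N(C3CCCC3)CC(=O)N4C)cc2)CC1`. It differs from compound 1 by 4-methylpiperidin-1-yl in place of methoxy on an aromatic carbon. Among the compounds with values here, no measured step bears on this exchange, so no size of step in this assay can be derived from the data; the only guidance is that all three measured compounds, including compound 3 with a saturated nitrogen ring on an aromatic carbon, sit at the limit.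

Compound 4 is therefore expected to sit near that limit too, with an estimated value of 30000 nM, ranging from 8000 nM to 100000 nM. This estimate corresponds to an expected step of a number no higher from compound 1 to compound 4 (the limit leaves the size open).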

Compound 4, half-maximal inhibitory concentration: > 30000 nM
Compound 4: a limit, no number; the forecaster's own chance of this, stated with the estimate: 70%; the middle value sits exactly at the limit.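

In this assay compound 4 gives > 30000 nM as a limit and not a number. Compound 1 also stands at a limit, so the step between compound 1 and compound 4 cannot be read: the limit of > 30000 nM in this assay, at which 4 of the 4 values shown sit. The compounds shown leave open which change to the shared core, if any, would give a measurable value in this assay.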